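The source may report more compounds than this note shows. Statements on the series, on what has been measured and on what is new or still open speak of the compounds shown alone.

The measurements come from a functional assay on MIA PaCa-2 cells (Homo sapiens) for inhibition, read by MTT assay, with a stated time of 7 days; a lower number here means a stronger inhibitor, a higher number a weaker inhibitor. Compound 1, `CCN(CC)S(=O)(=O)c1ccc(S(=O)(=O)N2CCC[C@@H](C(=O)N3CCN(c4nc(C(F)(F)F)no4)CC3)C2)cc1`, gives 600 nM in this assay, which is the lowest of the two numbers shown. Compound 2, `CCOC(=O)C1CN(S(=O)(=O)c2ccc(S(=O)(=O)N(CC)CC)cc2)C1`, gives 13900 nM in this assay, a gap from compound 1 that lies well beyond the scatter. Compound 3, `CCOC(=O)[C@@H]1CCCN(S(=O)(=O)c2cccc(S(=O)(=O)N(CC)CC)c2)C1`, returns only a limit of the assay, > 30000 nM, and no number; this is the limit of > 30000 nM in this assay, at which 1 of the 3 values shown sits. Going by the values given here, no two of these measured compounds differ in one place only, so no single measured step is available to lean on.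

Compound 4, `CCN(CC)S(=O)(=O)c1ccc(S(=O)(=O)N2CCC[C@@H](C(=O)N3CCN(c4nc(C(C)C)no4)CC3)C2)cc1`, differs from compound 1 in one place: isopropyl in place of trifluoromethyl on an aromatic carbon. Among the compounds with values here, with no measured step of this kind among the compounds above, the expectation for compound 4 rests on compound 1 alone. The step from compound 1 to compound 4 is expected to be small, a 2.0-fold higher number from compound 1 to compound 4 (0.30 log units; within the scatter), toward a slightly higher number but near the edge of the usual scatter rather than clearly beyond it. Compound 4 is therefore estimated to give 1200 nM in this assay, with a range from 400 nM to 4000 nM.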

Compound 4, half-maximal inhibitory concentration: 50 nM
For compound 4 the middle estimate is 24-fold (1.38 log units) above the measured one; measured number outside the range, below it.
By their numbers in this assay, from the lowest: compound 4; then compound 1; then compound 2. At a limit, above all of these: compound 3.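

In this assay, isopropyl in place of trifluoromethyl, on the aromatic carbon between two ring nitrogen atoms, gives a 12-fold lower number from compound 1 to compound 4 (1.08 log units; beyond the scatter), the first measured change in one place among these compounds and a large one, so this carbon is a place where the group clearly matters to the read-out and the rest of the molecule need not change for the number to move. Neither group carries a ring, a hydrogen-bond donor or acceptor, or a net charge, so the step separates two groups that are alike on those counts and differ in fluorine against carbon atoms. Nothing measured here accounts for the size of this step, and no property of either group is available to explain it.

With only trifluoromethyl and isopropyl shown on this carbon, it remains open whether the number follows any trend across groups such as methyl, tert-butyl, a cyclopropyl ring, an amine or a carboxylic acid. Going by these compounds, it is also open whether the same swap would give a step of this size on a core other than that of compound 1.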